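The source may hold more compounds than are shown below. What is called first, only, known or untested is meant among the compounds shown, and "the series" means these compounds.

Of the compounds shown here, three have been tested so far in a functional assay on Jurkat cells (Homo sapiens) for cytotoxicity, read by MTT assay, with a stated time of 72 h (on this read-out higher numbers stand for weaker inhibition and lower numbers for stronger inhibition), and a fourth still awaits its result. Compound 3 `COC(=O)c1sc2ccccc2c1Nc1cc(OC)c(OC)c(OC)c1` gives 490 nM in this assay. Compound 1 `CCOC(=O)c1sc2ccccc2c1Nc1cc(OC)c(OC)c(OC)c1` carries the change methyl in place of hydrogen on a saturated chain carbon bound to an oxygen next to a carbonyl group and gives 3020 nM in this assay; the step is a 6.2-fold higher number from compound 3 to compound 1 (0.79 log units; beyond the scatter). Compound 2 `COC(=O)c1sc2ncccc2c1Nc1cc(OC)c(OC)c(OC)c1` is built on a different core from compound 3, and the difference between the two cores is not broken down here; in this assay compound 2 gives 1110 nM, a number that lies between those of compound 3 and compound 1.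

Compound 4 `CCOC(=O)c1sc2ncccc2c1Nc1cc(OC)c(OC)c(OC)c1` is the compound still to be measured. It differs from compound 2 by methyl in place of hydrogen on a saturated chain carbon bound to an oxygen next to a carbonyl group, which is the same change that leads from compound 3 to compound 1, made here on the core of compound 2 instead. Among the four compounds this change occurs twice in all, and only one occurrence has been measured. That measured step was seen on a different core, so it cannot be taken for granted that a step of the same size will follow here. A step in the same direction and of a similar size is nonetheless expected because the step of a 6.2-fold higher number from compound 3 to compound 1 (0.79 log units; beyond the scatter) lies beyond the scatter. For compound 4 the expected step is a 5.4-fold higher number from compound 2 to compound 4 (0.73 log units; beyond the scatter). Compound 4 is therefore expected to give 6000 nM in this assay, most likely between 2500 nM and 15000 nM.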

Compound 4, half-maximal inhibitory concentration: 8450 nM
Beside the measured number, compound 4's estimate is 1.4-fold (0.15 log units) below it, and the stated range covers the measured number.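

In this assay, lengthening methoxycarbonyl to ethoxycarbonyl on the second core gives a 7.6-fold higher number from compound 2 to compound 4 (0.88 log units; beyond the scatter), so the added methyl again goes with weaker inhibition. Set beside the step on the first core, the change has much the same size on both cores: the same change on two cores in this assay, a 6.2-fold higher number (0.79 log units; beyond the scatter) from compound 3 to compound 1 and a 7.6-fold higher number (0.88 log units; beyond the scatter) from compound 2 to compound 4, 1.2-fold (0.09 log units) apart, within the scatter of two such steps. This shows that, within this pair of cores, the step measured on one core was a fair guide to the step on the other, but two cores are too few to show that it would carry over to any other core, and these numbers do not explain why the added methyl weakens inhibition.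

The compounds shown hold only methoxycarbonyl and ethoxycarbonyl at this place, so it remains open whether a longer chain, such as propoxycarbonyl, would weaken inhibition further, and how a carboxylic acid or an amide would compare. On these data alone, the methoxy groups are also the same in all four compounds, so it is equally open whether the step would keep its size if they were exchanged for other groups, such as hydroxy groups.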